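From carboxy to propoxycarbonyl on the shared core

A few compounds are considered here, and "the series" means these few. Any claim that something is new, unique, unknown or untested is made for them only; others in the source may bear on it.

In a functional assay on cells (Platelet, Homo sapiens) for inhibition (on this read-out lower numbers stand for stronger inhibition and higher numbers for weaker inhibition), compound 3 `O=C(O)c1ccc(-c2nn(Cc3ccccc3)c3ccccc23)cc1` stands at > 10000 nM, which is a limit. Compound 1 `CCOC(=O)c1ccc(-c2nn(Cc3ccc(OC)cc3)c3ccccc23)cc1` gives > 10000 nM, also a limit. Compound 2 `CCOC(=O)c1ccc(-c2nn(Cc3cccnc3)c3ccccc23)cc1` gives > 10000 nM, again a limit. The whole set therefore reads (the limit of > 10000 nM in this assay, at which 3 of the 3 values shown sit). For the measured compounds named here, the only measured step is a step that the two limits leave unreadable from compound 1 to compound 2, so it offers no size to carry over. Compound 4 `CCCOC(=O)c1ccc(-c2nn(Cc3ccccc3)c3ccccc23)cc1` follows through (propyl in place of hydrogen on an oxygen next to a carbonyl group), with propyl in place of hydrogen on an oxygen next to a carbonyl group. With no readable size to draw on, the expected change is uncertain, at most a modest move toward stronger inhibition, and the reading may well stay at the limit: an at least 1.6-fold lower number from compound 3 to compound 4 (0.22 log units; that floor lies within the scatter). Compound 4 is estimated at 6000 nM, within an expected range of 500 nM to 20000 nM.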

Compound 4, half-maximal inhibitory concentration: > 10000 nM
Compound 4: no number, only a limit (the forecaster's own chance of this, stated with the estimate: 55%); middle value at least 1.6-fold (0.22 log units) from the limit.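

Compound 3 and compound 4 both stand at a limit, so the change from carboxy to propoxycarbonyl cannot be read as a step. The compounds shown leave open which change on the shared core, if any, would give a readable number: the limit of > 10000 nM in this assay, at which 4 of the 4 values shown sit.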